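The compounds below may be only part of what the source reports. "The series", "measured", "known", "first", "only" and "open" are said of these compounds alone.

Compound 1 `CCCCCCCCCCCCCCC(COCc1ccccc1)NC(=O)CCCC(=O)OC` was tested in an ADME assay on cells (Splenocyte, Mus musculus, strain BALB/c) for cytotoxicity, read by MTT assay, tested at 10 ug/mL (a lower number here means a weaker effect, a higher number a stronger effect of the compound at the concentration tested), where compound 1 gives 2.5%. Two single changes to it were examined. In compound 2 `CCCCCCCCCCCCCCC(COCc1ccccc1)N(CC)CC` the core differs by a group of 5 heavy atoms (4 carbon, 1 nitrogen; no ring) in place of a group of 10 heavy atoms (6 carbon, 1 nitrogen, 3 oxygen; no ring), on a saturated chain carbon bound to two saturated chain carbons; in this assay compound 2 gives 15.6%, a step of a number 13.1 percentage points higher from compound 1 to compound 2 (beyond the scatter). In compound 3 `CCCCCCCCCCCCCCC(CO)NC(=O)CCCC(=O)OC` the change is hydrogen in place of benzyl on an oxygen on a saturated carbon; in this assay compound 3 gives 18.9%, a step of a number 16.4 percentage points higher from compound 1 to compound 3 (beyond the scatter). For the measured compounds named here, for compound 2 and compound 3 no step is laid out; their two numbers lie within the scatter of each other, so nothing can be said about which is higher.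

Compound 4 `CCCCCCCCCCCCCCC(CO)N(CC)CC` has not yet been measured in this assay. It carries the same change relative to compound 2 that compound 3 carries relative to compound 1, namely (hydrogen in place of benzyl on an oxygen on a saturated carbon); the surroundings of the place are described in the same words for both pairs, so this is the same change made on a different core. Since the earlier instance of this change gave a number 16.4 percentage points higher from compound 1 to compound 3 (beyond the scatter), the step from compound 2 to compound 4 is expected to be a number 12.4 percentage points higher from compound 2 to compound 4 (beyond the scatter), with the caveat that one prior example is a thin basis. On that footing the estimate for compound 4 in this assay is 28%, with a range from 12% to 45%.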

Compound 4, a percentage reported as activity, at one concentration (the size of the read-out at that concentration, not a potency): 12.8%
Compound 4: middle estimate off by 15.2 percentage points, on the high side; the range from low to high includes it.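

On the core of compound 2, exchanging benzyl for hydrogen on the oxygen did not repeat what the same exchange had done on the core of compound 1: in this assay it gives a number 2.8 percentage points lower from compound 2 to compound 4 (within the scatter), so no change can be claimed for this pair. The two instances of the change therefore do not agree, and the step seen on one core cannot be carried over as a fixed amount to the other: the same change on two cores in this assay, a number 16.4 percentage points higher (beyond the scatter) from compound 1 to compound 3 and a number 2.8 percentage points lower (within the scatter) from compound 2 to compound 4, 19.2 percentage points apart, beyond the scatter of two such steps. This shows that the outcome of removing the benzyl group depends on the core that carries it in this pair of cores, but it does not show which feature of the cores is responsible, and two pairs give no rule for any further core, nor does a read-out at one concentration say anything about potency.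

The compounds shown leave open whether the same dependence on the core would appear with another group on that oxygen, such as methyl or acetyl, in place of benzyl or hydrogen. They also leave open how the change would behave on a core carrying a carboxylic acid in place of the methyl ester, a primary amine in place of the diethylamino group, or a shorter chain.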